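Thioester in Place of Isopentyl Ester: Lipophilicity Outlook

The source may report more compounds than this note shows. Statements on the series, on what has been measured and on what is new or still open speak of the compounds shown alone.

Of the compounds shown here, three have been measured so far. Compound 1 `CC(/C=C/CC(C)CCCC(C)C)=C\C(=O)O` is the smallest of them, and in a physicochemical assay for lipophilicity (on this read-out lower numbers stand for lower lipophilicity and higher numbers for higher lipophilicity), compound 1 gives 5.95. Compound 2 `COC(C)(C)CCCC(C)C/C=C/C(C)=C/C(=O)OCCC(C)C` is the largest, and in this assay compound 2 gives 7.03. Compound 3 `CCOC(=O)/C=C(C)/C=C/CC(C)CCCC(C)(C)OC(C)=O` sits between the two in size, and in this assay compound 3 gives 5.57. Among these three numbers compound 2 stands highest: compound 1 is its nearest neighbour, at a distance beyond the scatter, and compound 3 lies furthest from it, also beyond the scatter. Within the data shown here, none of the three pairs differs in only one place, so no single step between measured compounds can be read off.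

Compound 4 `C#CCSC(=O)/C=C(C)/C=C/CC(C)CCCC(C)(C)OC` has not yet been measured. It differs from compound 2 in one place:

propargylsulfanyl in place of isopentyloxy on a carbonyl carbon

Because compound 2 gives 7.03 and the entering propargylsulfanyl group brings fewer heavy atoms than the leaving isopentyloxy group, the step from compound 2 to compound 4 in this assay is expected to be a drop beyond the scatter, of about a number 0.93 log units lower from compound 2 to compound 4 (beyond the scatter). For compound 4 the expected value in this assay is 6.1, with a range from 5.5 to 6.7.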

Compound 4, partition coefficient: 5.9
Compound 4: middle estimate off by 0.20 log units, on the high side; low and high end bracket the measured number.
By their numbers in this assay, from the lowest: compound 3; then compounds 4 and 1 (each within the scatter of the next); then compound 2.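

The series now has its first step that can be read at a single place: in this assay, the exchange of isopentyloxy for propargylsulfanyl on a carbonyl carbon whose other neighbour is a double-bonded chain carbon gives a number 1.13 log units lower from compound 2 to compound 4 (beyond the scatter), a large step. The earlier compounds shown here differed from one another in more than one place, so they could not show that a change confined to this carbonyl carbon moves the read-out by more than the scatter; this single change replaces a group of 6 heavy atoms (5 carbon, 1 oxygen) with one of 4 heavy atoms (3 carbon, 1 sulfur) and a triple bond, while the hydrogen-bond donor and acceptor counts stay the same. No measured property of either group is available to account for the size of this step.

This single step leaves open how much of the change goes with the sulfur in place of oxygen and how much with propargyl in place of isopentyl. An isopentylsulfanyl or a propargyloxy group on the same carbonyl carbon, compared with compound 2 and compound 4, would divide the step between the two.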